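A few compounds are considered here, and "the series" means these few. Any claim that something is new, unique, unknown or untested is made for them only; others in the source may bear on it.

Measured so far in a functional assay on U-87MG ATCC cells for antiproliferative activity against U-87 MG (Homo sapiens), read by MTT assay, with a stated time of 48 h, tested at 10 uM; on this read-out lower numbers stand for a stronger effect and higher numbers for a weaker effect at the one concentration tested:
compound 1 `COc1ccc(-c2nc(SCC(=O)c3sc(-c4ccccc4)nc3C)[nH]c(=O)c2C#N)cc1` gives 90.4%
compound 2 `COc1ccc(-c2nc(SCC(=O)c3sc(-c4ccc(Cl)cc4)nc3C)[nH]c(=O)c2C#N)cc1` gives 88.3%
compound 3 `COc1ccc(-c2nc(SCC(=O)c3sc(-c4ccccc4)nc3C)[nH]c(=O)c2C#N)cc1OC` gives 69.8%

Within this set the change chloro in place of hydrogen on an aromatic carbon produced a number 2.1 percentage points lower from compound 1 to compound 2 (within the scatter), so the two values are not told apart by this read-out. The core of compound 3 differs from that of compound 1 by methoxy in place of hydrogen on an aromatic carbon, and this gave a number 20.6 percentage points lower from compound 1 to compound 3 (beyond the scatter), which makes compound 3 the lowest number of the three.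

Compound 4 `COc1ccc(-c2nc(SCC(=O)c3sc(-c4ccc(Cl)cc4)nc3C)[nH]c(=O)c2C#N)cc1OC` is not yet measured. It carries the change chloro in place of hydrogen on an aromatic carbon on the core of compound 3, the same change as the one already seen, at the same place. The step is expected to be small, estimated at a number 2.8 percentage points lower from compound 3 to compound 4 (within the scatter), because the earlier occurrence of this change gave only a number 2.1 percentage points lower from compound 1 to compound 2 (within the scatter). For compound 4 a value of 67% is expected, with a likely range from 55% to 80%.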

Compound 4, a percentage reported as activity, at one concentration (the size of the read-out at that concentration, not a potency): 83.3%
The estimate for compound 4 lay 16.3 percentage points below the measured number; measured number outside the range, above it.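

In this assay, the chloro step does not carry from one core to the other: the same change on two cores in this assay, a number 2.1 percentage points lower (within the scatter) from compound 1 to compound 2 and a number 13.5 percentage points higher (beyond the scatter) from compound 3 to compound 4, 15.6 percentage points apart, beyond the scatter of two such steps
The methoxy step likewise depends on what else the core carries: the same change on two cores in this assay, a number 20.6 percentage points lower (beyond the scatter) from compound 1 to compound 3 and a number 5 percentage points lower (within the scatter) from compound 2 to compound 4, 15.6 percentage points apart, beyond the scatter of two such steps
Chloro on the core of compound 3 gave a number 13.5 percentage points higher from compound 3 to compound 4 (beyond the scatter), and methoxy on the core of compound 2 gave a number 5 percentage points lower from compound 2 to compound 4 (within the scatter), so the two changes do not add up across these four compounds; this shows that the steps depend on the core, but not why, nor how either change would behave on any further core.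

Open, going by these compounds, is whether an amine or a carboxylic acid in place of chloro would also differ between the two cores. Also open, on these data alone, is whether these differences persist across a range of concentrations, as one concentration gives no potency.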